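Compound 3 to compound 4: carboxyphenoxy linker variants

The compounds below may be only part of what the source reports. "The series", "measured", "known", "first", "only" and "open" are said of these compounds alone.

Three measured members share one core. In an assay on isolated protein for agonist activity at Bile acid receptor (Homo sapiens), read by FRET (on this read-out lower numbers stand for smaller maximal responses and higher numbers for larger maximal responses), compound 1 `CN(Cc1ccc(C(=O)O)cc1)c1ccc(OCc2c(-c3c(Cl)cccc3Cl)noc2C2CC2)nc1C(F)(F)F` gives 109%. In the same assay, compound 2 `CC(c1ccc(OCc2c(-c3c(Cl)cccc3Cl)noc2C2CC2)nc1C(F)(F)F)N(C)c1ccc(C(=O)O)cc1` gives 102%. Compound 3 `O=C(O)c1ccccc1OCc1ccc(OCc2c(-c3c(Cl)cccc3Cl)noc2C2CC2)nc1C(F)(F)F` gives 91%, the lowest of the three numbers, beyond the scatter below both compound 1 and compound 2. Among the compounds with values here, the one single-point step recorded so far runs to compound 3: a number 18 percentage points lower from compound 1 to compound 3 (beyond the scatter).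

Compound 4 `CC(Oc1cccc(C(=O)O)c1)c1ccc(OCc2c(-c3c(Cl)cccc3Cl)noc2C2CC2)nc1C(F)(F)F` is not yet measured. Relative to compound 3 the difference is 1-(3-carboxyphenoxy)ethyl in place of (2-carboxyphenoxy)methyl on an aromatic carbon. Within the data shown here, only the step from compound 1 to compound 3 touches the same position, and it was modest. The branching on the linker carbon has a loose parallel in compound 1 at 109% and compound 2 at 102%, two values within the scatter of each other. Among the measured compounds shown here, the carboxyl moving from the 2- to the 3-position of the phenoxy ring has no measured counterpart. A small step is therefore expected, with no clear direction, and none beyond the scatter would not be surprising. For compound 4 the estimate is 95%, within 80% to 110%. The expected step is a number 4 percentage points higher from compound 3 to compound 4 (within the scatter).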

Compound 4, largest response reached (reported as efficacy), in percent of the reference or control that the assay uses: 102%
Estimate against measurement, compound 4: 7 percentage points below; the range from low to high includes it.
By their numbers in this assay, from the lowest: compound 3; then compounds 2, 4 and 1 (each within the scatter of the next).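

In this assay, replacing (2-carboxyphenoxy)methyl with 1-(3-carboxyphenoxy)ethyl gives a number 11 percentage points higher from compound 3 to compound 4 (beyond the scatter), so the position responds to a change within the carboxyphenoxy side chains and not only to the exchange of an amino-linked chain for an ether-linked one. The low number of compound 3 therefore does not hold for every carboxyphenoxy chain here: the comparison with the amino-linked chains shows no change at the digits printed from compound 2 to compound 4 (within the scatter) and a number 7 percentage points lower from compound 1 to compound 4 (within the scatter), so a chain joined through the phenoxy oxygen can read like both of them. The data offer no explanation for the difference between compound 3 and compound 4, as nothing measured beyond these maximal responses bears on it.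

The step combines a branch on the linker carbon with a different placement of the carboxyl on the phenoxy ring, so the share of each in the gain cannot be separated from these compounds. Also open, from the compounds shown here alone, is whether the position needs a carboxylic acid at all, as a tetrazole or a primary amide in its place would test.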